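Removing the Nitro Group From an Indole Enone

A few compounds are considered here, and "the series" means these few. Any claim that something is new, unique, unknown or untested is made for them only; others in the source may bear on it.

Compound 1 `CC(=O)/C(=C/c1c(-c2ccccc2)[nH]c2ccccc12)C(=O)c1ccccc1`: 11000 nM
Compound 2 `CCOC(=O)/C(=C/c1c(-c2ccccc2)[nH]c2ccccc12)C(=O)c1ccc([N+](=O)[O-])cc1`: 2200 nM

Both compounds were tested in a functional assay on CCRF-SB cells (Homo sapiens) for cytotoxicity, read by MTT assay, with a stated time of 96 h; on this read-out lower numbers stand for an effect already at smaller amounts and higher numbers for an effect only at larger amounts of compound. Compound 2 stands at the lowest of the two numbers; compound 1 sits beyond the scatter above it, but differs from compound 2 in two places at once. Compound 3 `CCOC(=O)/C(=C/c1c(-c2ccccc2)[nH]c2ccccc12)C(=O)c1ccccc1` differs from compound 2 only by hydrogen in place of nitro on an aromatic carbon. Going by the values given here, no measured pair shows this change alone, so a step toward higher numbers of moderate size is expected, a 2.0-fold higher number from compound 2 to compound 3 (0.31 log units; beyond the scatter). Compound 3 is expected to give 4500 nM, within 1500 nM to 13000 nM.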

Compound 3, half-maximal effective concentration: 9600 nM
Compound 3: the middle estimate sits 2.1-fold (0.33 log units) below what was measured; measured number inside the range.
By their numbers in this assay, from the lowest: compound 2; then compounds 3 and 1 (each within the scatter of the next).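

In this assay, hydrogen in place of nitro on an aromatic carbon gives a 4.4-fold higher number from compound 2 to compound 3 (0.64 log units; beyond the scatter), so on this ring the nitro group goes with the lower number. Ethoxy in place of methyl on a carbonyl carbon gives a 1.1-fold lower number from compound 1 to compound 3 (0.06 log units; within the scatter), so this change does not separate the two compounds. Nothing available explains either result.

Going by these compounds, whether an amine or a nitrile on that same aromatic carbon would give a number nearer compound 2 or compound 3 stays open. So does the effect of a longer chain in place of ethoxy.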